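Dimethyl groups on the benzoyl ring: compound 3 to compound 4

The source may hold more compounds than are shown below. What is called first, only, known or untested is meant among the compounds shown, and "the series" means these compounds.

Compound 3 `O=C(CCN(Cc1ccc(C(=O)NO)cc1)C(=O)c1ccccc1)NCc1ccccc1` gives 5940 nM in a functional assay on G55T2 cells (Homo sapiens) for antiproliferative activity, read by WST assay, with a stated time of 72 h; a higher number here means a weaker inhibitor, a lower number a stronger inhibitor. Among the compounds with values here, that is the highest number among the three compounds measured so far. Within the data shown here, compound 1 `CN(C)c1ccc(C(=O)N(CCC(=O)NCc2ccc(Cl)cc2)Cc2ccc(C(=O)NO)cc2)cc1` gives 460 nM, and compound 2 `Cc1ccc(NC(=O)CCN(Cc2ccc(C(=O)NO)cc2)C(=O)c2ccc(N(C)C)cc2)cc1` gives 330 nM; both carry a dimethylamino group on the benzoyl ring that compound 3 lacks, and both also differ from compound 3 in the amide substituent, so no single step links them to it.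

Compound 4 `Cc1cc(C)cc(C(=O)N(CCC(=O)NCc2ccccc2)Cc2ccc(C(=O)NO)cc2)c1` is not yet measured. Its difference from compound 3 is 3,5-dimethylphenyl in place of phenyl on a carbonyl carbon.

Among the measured compounds shown here, the only measured step, a 1.4-fold lower number from compound 1 to compound 2 (0.14 log units; within the scatter), changes the amide substituent and therefore says nothing directly about substitution on the benzoyl ring. The values of compound 1 and compound 2 beside compound 3 show only that a more elaborated benzoyl ring goes with a lower number, but that comparison mixes two changes. On this thin basis a modest decrease, possibly within the scatter, is the most that can be expected of the step from phenyl to 3,5-dimethylphenyl.

Compound 4 is therefore estimated at 3000 nM, with a range of 1000 nM to 9000 nM, which is an expected step of a 2.0-fold lower number from compound 3 to compound 4 (0.30 log units; within the scatter).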

Compound 4, half-maximal inhibitory concentration: 4250 nM
Estimate against measurement, compound 4: 1.4-fold (0.15 log units) below; measured number inside the range.
By their numbers in this assay, from the lowest: compounds 2 and 1 (each within the scatter of the next); then compounds 4 and 3 (each within the scatter of the next).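

In this assay, within the data shown here, the first comparison that alters only the group on this carbonyl carbon gives a 1.4-fold lower number from compound 3 to compound 4 (0.15 log units; within the scatter), so compound 3 and compound 4 cannot be told apart, and 3,5-dimethylphenyl reads the same as phenyl here. The earlier compounds shown here could not show this, as each of the two that carry a dimethylamino group differs from compound 3 in the amide substituent as well as on the benzoyl ring. The position therefore accepts two added methyl groups with no readable consequence in this assay, although this single pair sets no rule for other groups at the same place, and nothing available here bears on the reason for this result.

The compounds shown leave open what a dimethylamino group does by itself on the benzoyl ring when the benzyl amide of compound 3 is kept, since that single change does not appear among them. They also leave open how a methoxy group, a morpholine ring or a single methyl group would read at this place on the ring.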